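Trifluoromethyl to Nitro Exchange on Two Related Cores

The source may report more compounds than this note shows. Statements on the series, on what has been measured and on what is new or still open speak of the compounds shown alone.

Measured compounds in a functional assay on DU-145 cells (Homo sapiens) for antiproliferative activity, read by MTT assay, with a stated time of 72 h; on this read-out lower numbers stand for stronger inhibition and higher numbers for weaker inhibition:
Compound 1, `FC(F)(F)c1ccc(COc2cccc(Nc3ncnc4cc5c(cc34)OCCOCCOCCOCCO5)c2)cc1`, gives 26900 nM.
Compound 2, `O=[N+]([O-])c1ccc(COc2cccc(Nc3ncnc4cc5c(cc34)OCCOCCOCCOCCO5)c2)cc1`, gives 13800 nM.
Compound 3, `FC(F)(F)c1ccc(COc2cccc(Nc3ncnc4cc5c(cc34)OCCOCCO5)c2)cc1`, gives only a limit of the assay, > 100000 nM.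

Compound 1 and compound 2 share one core and differ in a single place: nitro in place of trifluoromethyl on an aromatic carbon. The step in this assay is a 1.9-fold lower number from compound 1 to compound 2 (0.29 log units; within the scatter); the two values cannot be told apart with confidence.

Compound 3 carries a different core. The difference between the two cores is not broken down here. Compound 3 stands at the limit of the assay, where one of the three values sits (the limit of > 100000 nM in this assay, at which 1 of the 3 values shown sits), so no number is known for it.

Compound 4, `O=[N+]([O-])c1ccc(COc2cccc(Nc3ncnc4cc5c(cc34)OCCOCCO5)c2)cc1`, has not been measured. It stands to compound 3 as compound 2 stands to compound 1: nitro in place of trifluoromethyl on an aromatic carbon. The place of the change reads the same on both cores, so this is the same kind of change made on a different core.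

Going by the values given here, the only measured instance of the change, compound 1 to compound 2, stayed within the scatter. On that basis compound 4 is expected to move little from compound 3, with an expected step of a number no higher from compound 3 to compound 4 (the limit leaves the size open), and since compound 3 itself is only a limit, compound 4 is likely to be reported as a limit as well. The estimate for compound 4 in this assay is 100000 nM, with a range from 40000 nM to 300000 nM.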

Compound 4, half-maximal inhibitory concentration: > 100000 nM
Compound 4 ended at the assay's limit; the forecaster's own chance of this, stated with the estimate: 60%; the middle value lies on the limit itself.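

No step can be read from compound 3 to compound 4 in this assay, since each of the two values is only a limit of the assay: the limit of > 100000 nM in this assay, at which 2 of the 4 values shown sit.

The compounds shown leave open whether nitro in place of trifluoromethyl on an aromatic carbon changes the read-out on the core of compound 3 any more than it does on the core of compound 1.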